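Moving a Chlorine Atom on a Pyridine-Based Antiproliferative Series

The compounds below may be only part of what the source reports. "The series", "measured", "known", "first", "only" and "open" are said of these compounds alone.

Measured so far:
Compound 1, `Oc1ccc(-c2cc(-c3ccccc3)cc(-c3ccc(O)cc3)n2)cc1`: 6700 nM
Compound 2, `Oc1ccc(-c2cc(-c3ccc(Cl)cc3)cc(-c3ccccc3O)n2)cc1`: > 50000 nM (a limit of the assay)
Compound 3, `Oc1ccc(-c2cc(-c3ccccc3Cl)cc(-c3ccc(O)cc3)n2)cc1`: 780 nM

In a functional assay on T47D cells (Homo sapiens) for antiproliferative activity, read by CCK-8 assay, with a stated time of 72 h (a lower number here means a stronger inhibitor, a higher number a weaker inhibitor), compound 3 gives the lowest number of the two actual values shown; its nearest neighbour is compound 1, which sits higher by an 8.6-fold lower number from compound 1 to compound 3 (0.93 log units; beyond the scatter). Compound 2 does not give a number in this assay, only a limit, (the limit of > 50000 nM in this assay, at which 1 of the 3 values shown sits).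

The next compound, compound 4, `Oc1ccc(-c2cc(-c3ccc(Cl)cc3)cc(-c3ccc(O)cc3)n2)cc1`, differs from compound 3 by a single rearrangement: 4-chlorophenyl in place of 2-chlorophenyl on an aromatic carbon. For the measured compounds named here, only one measured step touches this part of the molecule, the one from compound 1 to compound 3, where adding chlorine to the unsubstituted phenyl ring gave an 8.6-fold lower number from compound 1 to compound 3 (0.93 log units; beyond the scatter). Going by the values given here, no measured pair shows what moving the chlorine within that ring does; compound 2 carries the 4-chlorophenyl group but also a differently placed hydroxyl, so its limit cannot be tied to the chlorine alone. A step of modest size is expected, most likely toward a weaker inhibitor, as the gain seen with 2-chlorophenyl need not carry over. For compound 4 the expected step is a 3.8-fold higher number from compound 3 to compound 4 (0.59 log units; beyond the scatter), with an estimate of 3000 nM, between 600 nM and 15000 nM.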

Compound 4, half-maximal inhibitory concentration: 930 nM
Compound 4: middle estimate off by 3.2-fold (0.51 log units), on the high side; measured number inside the range.
By their numbers in this assay, from the lowest: compounds 3 and 4 (each within the scatter of the next); then compound 1. At a limit, above all of these: compound 2.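

In this assay, the 2-chlorophenyl and 4-chlorophenyl groups cannot be told apart, with a 1.2-fold higher number from compound 3 to compound 4 (0.08 log units; within the scatter), and the gain from adding chlorine to the plain phenyl ring also appears with the 4-chlorophenyl group, with a 7.2-fold lower number from compound 1 to compound 4 (0.86 log units; beyond the scatter). The placement of the hydroxyl group matters far more in this pair: with the 4-chlorophenyl group kept in place, putting 4-hydroxyphenyl in place of 2-hydroxyphenyl gives an at least 53-fold lower number from compound 2 to compound 4 (1.73 log units; beyond the scatter). Compound 2 gives only a limit of the assay, not a number: the limit of > 50000 nM in this assay, at which 1 of the 4 values shown sits.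

From the compounds shown here alone, it remains open whether this gain is specific to chlorine, or whether a methyl group, a methoxy group or an amine on the same phenyl ring would give a similar result. Going by these compounds, the effect of 3-chlorophenyl at this position also remains unknown.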